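A few compounds are considered here, and "the series" means these few. Any claim that something is new, unique, unknown or untested is made for them only; others in the source may bear on it.

Compound 2 `CC(C)=CCc1cc(C(=O)Nc2cc3ccc(OCC4CCN(C)C4)c(C)c3oc2=O)ccc1O` gives 920 nM in a functional assay on SK-BR-3 cells (Homo sapiens) for antiproliferative activity (a lower number here means a stronger inhibitor, a higher number a weaker inhibitor), the highest of the three numbers, though its nearest neighbour compound 3 `CC(C)=CCc1cc(C(=O)Nc2cc3ccc(OCCCN(C)C(C)(C)C)c(C)c3oc2=O)ccc1O` at 880 nM and compound 1 `CC(C)=CCc1cc(C(=O)Nc2cc3ccc(OCC4CCCNC4)c(C)c3oc2=O)ccc1O` at 600 nM both lie within the scatter of it. Compound 4 `CC(C)=CCc1cc(C(=O)Nc2cc3ccc(OCCCNc4ccccc4)c(C)c3oc2=O)ccc1O` differs from compound 2 by 2-anilinoethyl in place of 1-methylpyrrolidin-3-yl on a saturated chain carbon bound to an oxygen on an aromatic ring. The measured steps that bear on this exchange are a 1.5-fold higher number from compound 1 to compound 2 (0.19 log units; within the scatter) and a 1.0-fold lower number from compound 2 to compound 3 (0.02 log units; within the scatter), both within the scatter, as is a 1.5-fold higher number from compound 1 to compound 3 (0.17 log units; within the scatter); none of them, however, introduced a 2-anilinoethyl group, so the data give no direct test of this change. The expected step is therefore a 1.1-fold higher number from compound 2 to compound 4 (0.04 log units; within the scatter), with a wide range. Compound 4 is estimated at 1000 nM, between 350 nM and 3000 nM.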

Compound 4, half-maximal inhibitory concentration: > 50000 nM
Compound 4 was reported as a limit; the forecaster's own chance of this, stated with the estimate: 5%; middle value at least 50-fold (1.69 log units) from the limit.
By their numbers in this assay, from the lowest: compounds 1, 3 and 2 (each within the scatter of the next). At a limit, above all of these: compound 4.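

The reading for compound 4 in this assay is a limit, not a number: the limit of > 50000 nM in this assay, at which 1 of the 4 values shown sits.

This position, on a saturated chain carbon bound to an oxygen on an aromatic ring, is not indifferent to its amine: compounds 1, 2 and 3 lie within the scatter of each other despite their different amines, yet the aniline brings an at least 54-fold higher number from compound 2 to compound 4 (1.73 log units; beyond the scatter), an at least 56-fold higher number from compound 3 to compound 4 (1.75 log units; beyond the scatter) and an at least 83-fold higher number from compound 1 to compound 4 (1.92 log units; beyond the scatter).

From the compounds shown here alone, whether this loss follows from the phenyl group itself or from its direct attachment to the nitrogen stays open. A benzylamino or methyl(phenyl)amino group on the same chain would separate the two.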